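Varying the group on the saturated chain carbon: compound 4

The compounds below may be only part of what the source reports. "The series", "measured", "known", "first", "only" and "open" are said of these compounds alone.

Three compounds of the series have numbers in a functional assay on RAW264.7 cells (Mus musculus) for inhibition, read by Griess assay, with stated times of 2 h and 24 h; on this read-out higher numbers stand for weaker inhibition and lower numbers for stronger inhibition. Compound 1 `COc1ccc([C@@H]2C/C(=N\O)c3c(O)cc(OCc4cn(CC5CC5)nn4)cc3O2)cc1O` gives 6320 nM. Going by the values given here, compound 3 `COc1ccc([C@@H]2C/C(=N\O)c3c(O)cc(OCc4cn(Cc5ccccc5Cl)nn4)cc3O2)cc1O` gives 13400 nM; the step of a 2.1-fold higher number from compound 1 to compound 3 (0.33 log units; beyond the scatter) is the only one-place comparison at hand. Compound 2 `CCn1cc(COc2cc(O)c3c(c2)O[C@H](c2ccc(OC)c(O)c2)CC3=O)nn1` gives 15000 nM, which sits within the scatter of compound 3 and beyond the scatter above compound 1. Compound 4 `COc1ccc([C@@H]2CC(=O)c3c(O)cc(OCc4cn(Cc5ccc(C(F)(F)F)cc5)nn4)cc3O2)cc1O` is not yet measured and differs from compound 2 by 4-(trifluoromethyl)phenyl in place of methyl on a saturated chain carbon bound to an aromatic nitrogen. Among the compounds with values here, the single step at the same place was modest, so for compound 4 in this assay a change of similar size, most likely toward a higher number or none beyond the scatter, is expected. Compound 4 is estimated at 18000 nM, in the range 7000 nM to 45000 nM. The expected step is a 1.2-fold higher number from compound 2 to compound 4 (0.08 log units; within the scatter).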

Compound 4, half-maximal inhibitory concentration: 17700 nM
Compound 4: middle estimate off by 1.0-fold (0.01 log units), on the high side, and the stated range covers the measured number.
By their numbers in this assay, from the lowest: compound 1; then compounds 3, 2 and 4 (each within the scatter of the next).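

On the core of compound 2, 4-(trifluoromethyl)phenyl in place of methyl on a saturated chain carbon bound to an aromatic nitrogen gives a step within the scatter in this assay (a 1.2-fold higher number from compound 2 to compound 4 (0.07 log units; within the scatter)). Going by these compounds alone, this place therefore takes an added aromatic ring on this core without a shift beyond the scatter, whereas the one earlier step here, on the core of compound 1, lay beyond it (a 2.1-fold higher number from compound 1 to compound 3 (0.33 log units; beyond the scatter)). No measurement at hand explains this difference.

Open: whether an amine or a carboxylic acid on this chain carbon would shift the number on either core, and how 4-(trifluoromethyl)phenyl reads on the core of compound 1.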